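This account rests on a few compounds, and the source may have more. Where it says the series, first, only, none or still open, it means among the compounds named here.

In an ADME assay on A549 cells (Homo sapiens) for cytotoxicity, read by CellTiter-Glo (on this read-out higher numbers stand for lower toxicity in this test and lower numbers for higher toxicity in this test), compound 1 `Cc1c(Cc2ccc(C(C)(C)C)cc2)c(=O)oc2cc(OCC(O)CN3CCC(C(N)=O)CC3)ccc12` gives 14700 nM. Compound 3 `Cc1c(Cc2ccc(-c3ccc(C=O)c(F)c3)cc2)c(=O)oc2cc(OCC(O)CN3CCC(C(N)=O)CC3)ccc12` gives 62400 nM in this assay. Compound 2 `Cc1c(Cc2ccc(-c3ccccc3)cc2)c(=O)oc2cc(OCC(O)CN3CCC(C(N)=O)CC3)ccc12` reaches > 100000 nM in this assay, which is a limit and not a number. Among the numbers shown, compound 3 stands highest, and its nearest neighbour is compound 1, the two being separated by a 4.2-fold higher number from compound 1 to compound 3 (0.63 log units; beyond the scatter). The other two measured steps were an at least 6.8-fold higher number from compound 1 to compound 2 (0.83 log units; beyond the scatter), which runs into the limit (the limit of > 100000 nM in this assay, at which 1 of the 3 values shown sits), and an at least 1.6-fold lower number from compound 2 to compound 3 (0.20 log units; that floor lies within the scatter). Compound 4 `Cc1c(Cc2ccc(-c3ccc(C#N)c(F)c3)cc2)c(=O)oc2cc(OCC(O)CN3CCC(C(N)=O)CC3)ccc12` differs from compound 3 in one place: cyano in place of formyl on an aromatic carbon. Among the measured compounds shown here, the measured step that bears most closely on this exchange is an at least 1.6-fold lower number from compound 2 to compound 3 (0.20 log units; that floor lies within the scatter), the only one that alters that ring, and it lay within the scatter. For the measured compounds named here, no measured step swaps one group on that ring for another, so the evidence for this change is thin. He therefore expects no movement beyond the scatter in this assay and estimates compound 4 at 65000 nM, between 30000 nM and 140000 nM, which would be an expected step of a 1.0-fold higher number from compound 3 to compound 4 (0.02 log units; within the scatter).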

Compound 4, half-maximal cytotoxic concentration: 29100 nM
For compound 4 the middle estimate is 2.2-fold (0.35 log units) above the measured one, and the stated range ends above it.
By their numbers in this assay, from the lowest: compounds 1 and 4 (each within the scatter of the next); then compound 3. At a limit, above all of these: compound 2.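

Exchanging one group for another at this carbon, ortho to a fluoro group, is not silent in this assay: a 2.1-fold lower number from compound 3 to compound 4 (0.33 log units; beyond the scatter), although formyl and cyano match in heavy atoms and hydrogen-bond acceptors. With 4-cyano-3-fluorophenyl in place of phenyl the step is an at least 3.4-fold lower number from compound 2 to compound 4 (0.53 log units; beyond the scatter), which clears the scatter as the floor for the formyl group did not, while with the same group in place of tert-butyl the step is a 2.0-fold higher number from compound 1 to compound 4 (0.30 log units; within the scatter), so that pair cannot be told apart. Compound 2 gives a limit and not a number: the limit of > 100000 nM in this assay, at which 1 of the 4 values shown sits.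

Going by these compounds, whether cyano alone sets this step stays open, for both formyl and cyano appear here only together with the fluoro group. How an amine, a carboxylic acid or a methyl ester at this carbon would read in this assay is also left open.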